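A few compounds are considered here, and "the series" means these few. Any claim that something is new, unique, unknown or untested is made for them only; others in the source may bear on it.

Measured compounds:
compound 1 `CC(=O)Nc1cccc(NC(=O)COc2ccc3c(=O)ccoc3c2)c1` — 2500 nM
compound 2 `O=C(COc1ccc2c(=O)ccoc2c1)Nc1cccc(NC(=O)c2ccc(Br)cc2)c1` — 303 nM
compound 3 `CCOc1ccc(C(=O)Nc2cccc(NC(=O)COc3ccc4c(=O)ccoc4c3)c2)cc1` — 17 nM

All three share one core and differ only in the group on the carbonyl carbon of the outer amide. In an assay on isolated protein for inhibition of Rho-associated protein kinase 1 (Homo sapiens), read by scintillation counting, radiometric assay and 33P incorporation, with a stated time of 40 min, in the presence of a further agent that is not named here (a lower number here means a stronger inhibitor, a higher number a weaker inhibitor), compound 3 gives 17 nM, the lowest of the three numbers. Compound 2 gives 303 nM, and compound 1 gives 2500 nM. The step of a 150-fold lower number from compound 1 to compound 3 (2.17 log units; beyond the scatter) shows how much the 4-ethoxyphenyl group contributes over methyl; the step of an 8.3-fold lower number from compound 1 to compound 2 (0.92 log units; beyond the scatter) shows that 4-bromophenyl gives a smaller gain, and the step of an 18-fold lower number from compound 2 to compound 3 (1.25 log units; beyond the scatter) shows that the change on the aromatic carbon itself carries a large part of the effect.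

Compound 4 `Cc1nc(C(=O)Nc2cccc(NC(=O)COc3ccc4c(=O)ccoc4c3)c2)cs1` is not yet measured. Its change from compound 3 is 2-methyl-1,3-thiazol-4-yl in place of 4-ethoxyphenyl on a carbonyl carbon. This replaces the group that gave the largest gain with a smaller ring that carries no ethoxy, so the steps from compound 1 to compound 3 and from compound 2 to compound 3 bear on it most directly, and both were large. A weaker inhibitor than compound 3 is therefore expected, though probably not as weak as compound 1, since an aromatic ring remains on the carbonyl carbon. The step is estimated as an 8.8-fold higher number from compound 3 to compound 4 (0.95 log units; beyond the scatter). Compound 4 is expected to give 150 nM, with a range from 40 nM to 600 nM.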

Compound 4, half-maximal inhibitory concentration: 473 nM
Estimate against measurement, compound 4: 3.2-fold (0.50 log units) below; the range from low to high includes it.
By their numbers in this assay, from the lowest: compound 3; then compounds 2 and 4 (each within the scatter of the next); then compound 1.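

The thiazole result shows that an aromatic ring on this carbonyl carbon does not by itself secure the low number of compound 3: 2-methyl-1,3-thiazol-4-yl gives up much of that gain, with a 28-fold higher number from compound 3 to compound 4 (1.44 log units; beyond the scatter), yet it still improves on methyl, with a 5.3-fold lower number from compound 1 to compound 4 (0.72 log units; beyond the scatter). Against 4-bromophenyl the same group shows a 1.6-fold higher number from compound 2 to compound 4 (0.19 log units; within the scatter), so in this assay these two groups cannot be told apart, although one is a six-membered ring of carbon only and the other a five-membered ring with two hetero atoms, and among the aromatic groups shown only 4-ethoxyphenyl stands clear of the others. Nothing available here explains why these groups differ or why the two match.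

The compounds shown leave open whether the advantage of compound 3 lies in the ethoxy group or in the six-membered ring that carries it, since the ring and its substituent change together from compound 3 to compound 4. A plain phenyl, a methoxy or longer alkoxy chain on the phenyl ring, or an ethoxy on the thiazole ring would separate these two contributions.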